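Swapping pentylphenyl for hydroxyphenyl on a shared core

The compounds below may be only part of what the source reports. "The series", "measured", "known", "first", "only" and "open" are said of these compounds alone.

The measurements available come from a functional assay on SW-620 cells (Homo sapiens) for antiproliferative activity, read by MTT assay, with a stated time of 72 h; a higher number here means a weaker inhibitor, a lower number a stronger inhibitor.
Compound 1 `O=C1O/C(=C\Cn2cc(-c3cc(F)cc(F)c3)nn2)C(OCc2ccccc2)=C1OCc1ccccc1`, measured value: > 100000 nM, a limit of the assay.
Compound 2 `CCCCCc1ccc(-c2cn(C/C=C3\OC(=O)C(OCc4ccccc4)=C3OCc3ccccc3)nn2)cc1`, measured value: > 100000 nM, a limit of the assay.
Compound 3 `CC(C)(C)OC(=O)N1CCN(C(=S)SCc2cn(C[C@H](O)[C@H]3OC(=O)C(OCc4ccccc4)=C3OCc3ccccc3)nn2)CC1`, measured value: > 100000 nM, a limit of the assay.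

Compound 2 therefore stands at the limit of this assay, not at a number, and so do compound 1 and compound 3 (the limit of > 100000 nM in this assay, at which 3 of the 3 values shown sit). Going by the values given here, the one step that joins two measured compounds, a step that the two limits leave unreadable from compound 1 to compound 2, cannot be read in size, since both ends are limits. Among the compounds with values here, compound 3 differs from the others in more than one place, so no step to it is counted.

The unmeasured compound 4 `O=C1O/C(=C\Cn2cc(-c3cccc(O)c3)nn2)C(OCc2ccccc2)=C1OCc1ccccc1` differs from compound 2 in one place: 3-hydroxyphenyl in place of 4-pentylphenyl on an aromatic carbon. Within the data shown here, no measured step shows how such a change acts in this assay. Among the measured compounds shown here, with every measured compound at the limit, and the only comparable step that the two limits leave unreadable from compound 1 to compound 2 unreadable, the plain expectation is that compound 4 also returns a limit rather than a number. The estimated step that the limit leaves unreadable from compound 2 to compound 4 is expected to stay within the scatter. Compound 4 is therefore estimated at 150000 nM, with a range from 50000 nM to 500000 nM, most likely reported as a limit.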

Compound 4, half-maximal inhibitory concentration: 69800 nM
For compound 4 the middle estimate is 2.1-fold (0.33 log units) above the measured one; low and high end bracket the measured number.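

Compound 4 is the only compound shown that gives a number rather than a limit in this assay, so this place, an aromatic carbon of a five-membered aromatic ring with 3 nitrogen, now has one readable result on the shared core. Putting 3-hydroxyphenyl in place of 4-pentylphenyl gives an at least 1.4-fold lower number from compound 2 to compound 4 (0.15 log units; that floor lies within the scatter), and putting it in place of 3,5-difluorophenyl gives an at least 1.4-fold lower number from compound 1 to compound 4 (0.15 log units; that floor lies within the scatter). Both steps are floors rather than measured sizes, so the real gain could be small or considerably larger, and the result alone does not settle whether the change matters beyond ordinary assay noise: the limit of > 100000 nM in this assay, at which 3 of the 4 values shown sit.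

The compounds shown leave open which part of 3-hydroxyphenyl goes with the readable value, and whether a methoxy group, an amine or a carboxylic acid in place of the hydroxyl would also give a number in this assay. From the compounds shown here alone, it also remains open whether 3-hydroxyphenyl would give a number on the rest of the structure of compound 3, which differs from the other compounds in more than one place.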